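Series note: compound 3 to compound 4

The source may report more compounds than this note shows. Statements on the series, on what has been measured and on what is new or still open speak of the compounds shown alone.

Within the data shown here, compound 3 `COc1cc(NC(=O)Nc2cc(Nc3ccc(F)c(Cl)c3)ncn2)cc(OC)c1` gives 53% in a functional assay on NCI-H1581 cells (Homo sapiens) for inhibition, read by MTT assay, with a stated time of 48 h, tested at 10 uM (on this read-out higher numbers stand for more inhibition at the one concentration tested (going by the name of the read-out) and lower numbers for less inhibition), and stands second highest of the three numbers known. Compound 1 `COc1ccc(F)cc1Nc1cc(NC(=O)Nc2c(Cl)cccc2Cl)ncn1` gives 73.1% and compound 2 `COc1cc(NC(=O)Nc2cc(Nc3ccc(C)c(C)c3)ncn2)cc(OC)c1` gives 20.1%. The change to compound 4 `COc1cc(NC(=O)Nc2cc(Nc3cc(F)ccc3OC)ncn2)cc(OC)c1` is 5-fluoro-2-methoxyphenyl in place of 3-chloro-4-fluorophenyl on a nitrogen on an aromatic ring. Among the measured compounds shown here, one measured step bears on this place: a number 32.9 percentage points higher from compound 2 to compound 3 (beyond the scatter), a large move from a change of the same group at the same nitrogen. Compound 1 carries the same 5-fluoro-2-methoxyphenyl on that nitrogen, though it differs elsewhere, and its value sits above that of compound 3. For compound 4 the expected step is a number 7 percentage points higher from compound 3 to compound 4 (within the scatter), not clearly beyond the scatter. Compound 4 is therefore estimated at 60%, within 35% to 80%.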

Compound 4, a percentage reported as inhibition, at one concentration (the size of the read-out at that concentration, not a potency): 42.1%
Compound 4: middle estimate off by 17.9 percentage points, on the high side; the range from low to high includes it.
By their numbers in this assay, from the lowest: compound 2; then compound 4; then compound 3; then compound 1.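

On the shared core, 5-fluoro-2-methoxyphenyl on this nitrogen gives a number 10.9 percentage points lower from compound 3 to compound 4 (beyond the scatter) and a number 22 percentage points higher from compound 2 to compound 4 (beyond the scatter) as well, so this group ranks between the two earlier aryl groups. With that group held constant, 3,5-dimethoxyphenyl in place of 2,6-dichlorophenyl on the amide-type nitrogen gives a number 31 percentage points lower from compound 1 to compound 4 (beyond the scatter) and so the high value of compound 1 cannot be credited to 5-fluoro-2-methoxyphenyl alone. Open, on these data alone, is whether an aliphatic amine such as morpholine or a carboxylic acid in place of these aryl groups would exceed compound 3. No measurement shown here explains these steps.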